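Notes on a difluorophenyl to dichlorophenyl swap

This account rests on a few compounds, and the source may have more. Where it says the series, first, only, none or still open, it means among the compounds named here.

Measured so far in a functional assay on A2780 cells (Homo sapiens) for cytotoxicity; on this read-out higher numbers stand for weaker inhibition and lower numbers for stronger inhibition:
- compound 1 `C[C@@H](C(=O)Nc1ncc(SCc2ncc(C(C)(C)C)o2)s1)c1ccccc1`: 900 nM
- compound 2 `CC(C)OC(=O)Nc1ncc(SCc2ncc(C(C)(C)C)o2)s1`: 640 nM
- compound 3 `CC(C)(C)c1cnc(CSc2cnc(NC(=O)Nc3c(F)cccc3F)s2)o1`: 240 nM

Compound 3 has the lowest number of the three, and both steps to it lie beyond the scatter: a 2.7-fold lower number from compound 2 to compound 3 (0.43 log units; beyond the scatter) and a 3.8-fold lower number from compound 1 to compound 3 (0.57 log units; beyond the scatter). The remaining step, a 1.4-fold lower number from compound 1 to compound 2 (0.15 log units; within the scatter), stays within the scatter.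

The next compound is compound 4 `CC(C)(C)c1cnc(CSc2cnc(NC(=O)Nc3c(Cl)cccc3Cl)s2)o1`, with the change 2,6-dichlorophenyl in place of 2,6-difluorophenyl on an amide-type nitrogen. The two modest steps into compound 3 bear on this only indirectly, since each replaces a whole group on the carbonyl carbon with (2,6-difluorophenyl)amino. For the measured compounds named here, no measured pair exchanges fluorine for chlorine, so the data favour no direction. The change here is narrower than those steps, and in this assay no step beyond the scatter is expected.

The estimate therefore stays close to compound 3 at 240 nM. The expected step is a 1.0-fold lower number from compound 3 to compound 4 (0.02 log units; within the scatter). For compound 4 the estimated value is 230 nM, with an expected range of 90 nM to 550 nM.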

Compound 4, half-maximal inhibitory concentration: 1500 nM
Beside the measured number, compound 4's estimate is 6.5-fold (0.81 log units) below it; measured number above the stated range.
By their numbers in this assay, from the lowest: compound 3; then compounds 2, 1 and 4 (each within the scatter of the next, the first and the last beyond it).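

In this assay, for the compounds shown here, 2,6-dichlorophenyl in place of 2,6-difluorophenyl on the amide-type nitrogen gives a 6.3-fold higher number from compound 3 to compound 4 (0.80 log units; beyond the scatter) and so shows that this position is sensitive to the identity of the halogen, which the earlier steps could not show because each replaced a whole group on the carbonyl carbon. The (2,6-difluorophenyl)amino group's gain over the other groups does not carry over to (2,6-dichlorophenyl)amino: against the isopropoxy of compound 2 the direction reverses, with a 2.3-fold higher number from compound 2 to compound 4 (0.37 log units; beyond the scatter) and against the 1-phenylethyl of compound 1 the step is a 1.7-fold higher number from compound 1 to compound 4 (0.22 log units; within the scatter) and thus no clear separation remains. Nothing available on these compounds offers an explanation for the difference between the two halogens.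

On these data alone, with only these two aryl groups in hand, it remains open whether the trend follows the halogen itself or would extend to groups such as unsubstituted phenyl, 2-chloro-6-fluorophenyl or 2,6-dimethylphenyl. As far as these compounds go, whether the same exchange behaves alike with a different group on the core, such as a methyl in place of the tert-butyl, also remains open.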